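Swapping one aminophenyl group for another on a sulfone

This account rests on a few compounds, and the source may have more. Where it says the series, first, only, none or still open, it means among the compounds named here.

compound 1 `COc1cc(OC)c(/C=C/S(=O)(=O)Cc2ccc(F)c(N)c2)c(OC)c1` gives 2500 nM
compound 2 `COc1ccc(CS(=O)(=O)/C=C/c2ccccc2OC)cc1N` gives 7500 nM

Both numbers come from a functional assay on DU-145 cells (Homo sapiens) for cytotoxicity, read by trypan blue exclusion, with a stated time of 96 h; a higher number here means a weaker inhibitor, a lower number a stronger inhibitor. Compound 1 holds the lower of the two numbers at 2500 nM, which makes it the stronger inhibitor of this pair, and the gap to compound 2 lies beyond the scatter. Within the data shown here, the two compounds differ in more than one place, so no measured step shows what a single change does.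

The next compound, compound 3 `COc1cc(OC)c(/C=C/S(=O)(=O)Cc2ccc(Cl)cc2N)c(OC)c1`, keeps the rest of compound 1 but carries 2-amino-4-chlorophenyl in place of 3-amino-4-fluorophenyl on a saturated chain carbon bound to a sulfonyl sulfur. With so little data, the direction of any effect in this assay cannot be argued firmly. The most likely outcome is a step no larger than the scatter, although a shift in either direction as large as the gap between the two measured compounds would not be surprising. The estimate amounts to an expected 1.2-fold higher number from compound 1 to compound 3 (0.08 log units; within the scatter) in this assay. For compound 3 the estimated value is 3000 nM (expected range 700 nM to 12000 nM).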

Compound 3, half-maximal inhibitory concentration: 2500 nM
Compound 3: middle estimate off by 1.2-fold (0.08 log units), on the high side; measured number inside the range.
By their numbers in this assay, from the lowest: compounds 1 and 3 (each within the scatter of the next); then compound 2.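

Among these compounds, this is the first measured step that changes only one place: on a saturated chain carbon bound to a sulfonyl sulfur, 2-amino-4-chlorophenyl replaces 3-amino-4-fluorophenyl, and this assay shows no change at the digits printed from compound 1 to compound 3 (within the scatter). This position therefore accepts a ring that swaps fluorine for chlorine and also moves the amino group, with no difference this read-out can detect. Since both features change in a single step, the result cannot show whether each change alone would leave the number unchanged or whether two opposing effects happen to cancel; no measurement shown explains the result.

As far as these compounds go, it remains open what each feature does alone, which a comparison of 3-amino-4-chlorophenyl with these two rings would help to separate. From the compounds shown here alone, it is also open whether the amino group is needed at all, and what a ring carrying a hydroxyl group or a carboxylic acid in its place would give at this position.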